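Triazole substituent variation in a fluorobromophenyl amidoxime series

The compounds below may be only part of what the source reports. "The series", "measured", "known", "first", "only" and "open" are said of these compounds alone.

Three compounds of one shared core differ only in the group on an aromatic carbon of the five-membered ring. Compound 1 `OCCCCc1cn(CCNc2nonc2/C(=N/O)Nc2ccc(F)c(Br)c2)nn1` carries 4-hydroxybutyl, and in an assay on isolated protein for inhibition of Indoleamine 2,3-dioxygenase 1 (Homo sapiens) (a higher number here means a weaker inhibitor, a lower number a stronger inhibitor), compound 1 gives 80 nM. Compound 2 `CC(O)c1cn(CCNc2nonc2/C(=N/O)Nc2ccc(F)c(Br)c2)nn1` carries 1-hydroxyethyl; in this assay compound 2 gives 53 nM. Compound 3 `O/N=C(\Nc1ccc(F)c(Br)c1)c1nonc1NCCn1cc(C2(O)CCCCC2)nn1` carries 1-hydroxycyclohexyl; in this assay compound 3 gives 62 nM, the second highest of the three numbers, with compound 2 nearest and compound 1 furthest, all three within the scatter of one another. The steps at this position have all been small: a 1.5-fold lower number from compound 1 to compound 2 (0.18 log units; within the scatter), a 1.3-fold lower number from compound 1 to compound 3 (0.11 log units; within the scatter) and a 1.2-fold higher number from compound 2 to compound 3 (0.07 log units; within the scatter).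

Compound 4 `CC(OCCO)c1cn(CCNc2nonc2/C(=N/O)Nc2ccc(F)c(Br)c2)nn1` is not yet measured. It differs from compound 3 by 1-(2-hydroxyethoxy)ethyl in place of 1-hydroxycyclohexyl on an aromatic carbon. All three measured steps bear on this change, since each swaps the group at the same aromatic carbon, and none moved the number beyond the scatter. A further swap at this position is therefore expected to give no step beyond the scatter in this assay, and the expected step is a 1.0-fold lower number from compound 3 to compound 4 (0.01 log units; within the scatter). For compound 4 the estimate in this assay is 60 nM, with a range from 25 nM to 150 nM.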

Compound 4, half-maximal inhibitory concentration: 134 nM
Estimate against measurement, compound 4: 2.2-fold (0.35 log units) below; the range from low to high includes it.
By their numbers in this assay, from the lowest: compounds 2, 3, 1 and 4 (each within the scatter of the next, the first and the last beyond it).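

In this assay, among the compounds shown here, this position no longer looks flat: 1-(2-hydroxyethoxy)ethyl in place of 1-hydroxycyclohexyl gives a 2.2-fold higher number from compound 3 to compound 4 (0.33 log units; beyond the scatter) and 2-hydroxyethyl on the oxygen of the 1-hydroxyethyl group gives a 2.5-fold higher number from compound 2 to compound 4 (0.40 log units; beyond the scatter) as the first steps here beyond the scatter, both of them modest. The pattern does not hold against all three earlier groups, since compound 1 goes against it: with 4-hydroxybutyl as the group that leaves, the result is a 1.7-fold higher number from compound 1 to compound 4 (0.22 log units; within the scatter) and that step stays within the scatter. The entering group has no ring and one more hydrogen-bond acceptor than 1-hydroxycyclohexyl, but no measurement at hand ties the steps to either difference or to any other cause.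

The compounds shown leave open whether the ether oxygen or the terminal hydroxyl of the new chain goes with these steps, a question that 1-methoxyethyl at the same aromatic carbon would help to settle. Also open, going by these compounds, is how this position responds to a group without a hydroxyl, such as an amine or a carboxylic acid, and whether a longer ether chain moves the number further.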